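Sulfanyl to methyl on the shared core: expected activation

The source may report more compounds than this note shows. Statements on the series, on what has been measured and on what is new or still open speak of the compounds shown alone.

Compound 1, `NNc1nc2c(N)ncnc2n1Cc1ccccc1`, was tested in a functional assay (spleen, spleen) for activation, with Mus musculus as the target; on this read-out lower numbers stand for an effect already at smaller amounts and higher numbers for an effect only at larger amounts of compound. In this assay compound 1 gives > 10 uM, which is a limit of the assay and not a number. Among the measured compounds shown here, compound 2, `Nc1ncnc2c1nc(S)n2Cc1ccccc1`, carries sulfanyl where compound 1 carries aminoamino, and in this assay compound 2 gives 10 uM, the only number among the two values shown. For the measured compounds named here, the one measured step, a number no higher from compound 1 to compound 2 (the limit leaves the size open), rests on the limit of > 10 uM in this assay, at which 1 of the 2 values shown sits, and so tells nothing about its size.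

Compound 3, `Cc1nc2c(N)ncnc2n1Cc1ccccc1`, differs from compound 2 by methyl in place of sulfanyl on an aromatic carbon. No measured step covers an exchange of sulfanyl for methyl; the single step shown concerns a different group and has no readable size. The expectation for compound 3 therefore rests on compound 2 alone, with the estimated step of no change at the digits printed from compound 2 to compound 3 (within the scatter) set within the scatter, and a marked chance that only a limit is reported, as for compound 1. Compound 3 is expected to give 10 uM in this assay, within 3 uM to 30 uM.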

Compound 3, minimum effective concentration: > 10 uM
Compound 3 gave a limit, no number (the forecaster's own chance of this, stated with the estimate: 45%); the middle value sits exactly at the limit.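

In this assay, among the compounds shown here, methyl in place of sulfanyl on an aromatic carbon, between two ring nitrogen atoms, gives a number no lower from compound 2 to compound 3 (the limit leaves the size open); this is the first step at this position that starts from a number. Of the three groups shown at this position, only sulfanyl gives a number, while aminoamino and methyl both end in a limit, and the step between those two cannot be read. The size of every step in the series stays open, since most of the values are limits and not numbers: the limit of > 10 uM in this assay, at which 2 of the 3 values shown sit.

On these data alone, whether the number for compound 2 is tied to the sulfur atom itself or to the hydrogen on it remains open, and a methylsulfanyl or hydroxyl group at the same place would bear on that question. As far as these compounds go, how a plain amine or a longer chain such as ethyl compares at this position, and how far compound 3 lies from compound 2, also remains open until a value at this position can be read as a number on both sides of a step.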